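The source may report more compounds than this note shows. Statements on the series, on what has been measured and on what is new or still open speak of the compounds shown alone.

Compound 1 `COc1cc([C@](O)(CCN(C)C)[C@@H](c2cc3cc(C#N)ccc3nc2OC)c2cccc(OC)c2F)cc(SC)n1` gives 28%
Compound 2 `COc1cccc([C@H](c2cc3cc(Br)ccc3nc2OC)[C@@](O)(CCN(C)C)c2cc(SC)nc(SC)c2)c1F` gives 66%

In an ADME assay on the whole organism (Mus musculus, strain CD-1) for pharmacokinetics, at a dose of 10 mg/kg by the oral route (on this read-out lower numbers stand for lower oral bioavailability and higher numbers for higher oral bioavailability), compound 2 holds the higher of the two numbers, and the gap between its 66% and the number for compound 1 lies beyond the usual scatter of repeated measurements.

The next molecule, compound 3 `COc1cccc([C@H](c2cc3cc(C#N)ccc3nc2OC)[C@@](O)(CCN(C)C)c2cc(SC)nc(SC)c2)c1F`, has cyano in place of bromo on an aromatic carbon and otherwise matches compound 2. Within the data shown here, no pair of measured compounds shows this single change on its own, so its size cannot be read directly from the data. Among the measured compounds shown here, the only hint comes from compound 1, which also carries the cyano group and gives 28% in this assay, but it differs from compound 3 elsewhere too, which makes the hint a weak one.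

A fall of moderate size, beyond the scatter, is therefore expected, and the estimated change is a number 21 percentage points lower from compound 2 to compound 3 (beyond the scatter), with considerable uncertainty. The estimated value for compound 3 is 45%, within an expected range of 24% to 66%.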

Compound 3, oral bioavailability: 28%
Beside the measured number, compound 3's estimate is 17 percentage points above it; low and high end bracket the measured number.
By their numbers in this assay, from the lowest: compounds 1 and 3 (each within the scatter of the next); then compound 2.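

In this assay, among these compounds, the swap of bromo for cyano on the aromatic carbon of the fused two-ring system gives a number 38 percentage points lower from compound 2 to compound 3 (beyond the scatter), a large step and the first direct reading of this change, which until now could only be guessed from compounds differing in more than one place. The second step, methylsulfanyl in place of methoxy on an aromatic carbon, gives no change at the digits printed from compound 1 to compound 3 (within the scatter), so with cyano at the fused system this other swap leaves the oral bioavailability where it was, and in this small set only the bromo for cyano swap moves the number. Nothing among the data shown accounts for the size of the fall on going from bromo to cyano.

One swap at one position cannot show whether bromo is unusually favourable or cyano unusually unfavourable, and a chloro group, a methyl group or a carboxamide on the same carbon would help to tell these apart. Going by these compounds, it also remains open whether bromo in place of cyano would bring the same large step on the core of compound 1, which carries methoxy where compound 3 carries methylsulfanyl.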